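Bis-amide series: a second chloro on compound 3

The source may hold more compounds than are shown below. What is called first, only, known or untested is meant among the compounds shown, and "the series" means these compounds.

Measured so far:
compound 1 `COc1ccccc1C(=O)Nc1cccc(NC(=O)c2ccc(Cl)c(Cl)c2)c1` gives > 30000 nM
compound 2 `O=C(Nc1cccc(NC(=O)c2ccccc2Cl)c1)c1cccc(Cl)c1` gives 2620 nM
compound 3 `O=C(Nc1cccc(NC(=O)c2cccc(Cl)c2)c1)c1ccc(Cl)cc1` gives > 30000 nM

In an in vitro functional assay on HEK293-A cells for antagonist activity at metabotropic glutamate receptor 5 (Rattus norvegicus), read by calcium flux (on this read-out lower numbers stand for stronger inhibition and higher numbers for weaker inhibition), compound 2 gives 2620 nM. Compound 3 gives > 30000 nM, which is a limit of the assay and not a number. Compound 1 likewise sits at a limit. Compound 4 `O=C(Nc1cccc(NC(=O)c2ccc(Cl)c(Cl)c2)c1)c1cccc(Cl)c1` differs from compound 3 by chloro in place of hydrogen on an aromatic carbon. Going by the values given here, the only quantified step, an at least 11-fold higher number from compound 2 to compound 3 (1.05 log units; beyond the scatter), changes the position of the chloro group and ends at a limit; no measured step adds a second chloro. Compound 1, which carries the same 3,4-dichlorophenyl group on a carbonyl carbon but a different second amide, also sits at the limit. Given (the limit of > 30000 nM in this assay, at which 2 of the 3 values shown sit), compound 4 is expected to stay at the limit, a step that the limit leaves unreadable from compound 3 to compound 4. Compound 4 is estimated at 40000 nM, range 15000 nM to 120000 nM.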

Compound 4, half-maximal inhibitory concentration: > 30000 nM
Compound 4 ended at the assay's limit (the forecaster's own chance of this, stated with the estimate: 75%); the middle value lies beyond the limit too.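

In this assay compound 4 gives > 30000 nM, which is a limit of the assay and not a number, so a second chloro on the 4-chlorophenyl group does not bring the series off the limit. Going by these compounds alone, with 3,4-dichlorophenyl in place of 2-chlorophenyl, the comparison with the one quantified compound reads as an at least 11-fold higher number from compound 2 to compound 4 (1.05 log units; beyond the scatter). The steps joining compound 4 to compound 1 and to compound 3 cannot be read, because both ends of each sit at a limit: the limit of > 30000 nM in this assay, at which 3 of the 4 values shown sit.

Still open, from the compounds shown here alone, is whether an amine or a carboxylic acid in place of the added chloro would give a measurable value. Also open, going by these compounds, is whether a second chloro on the 2-chlorophenyl group of compound 2 would keep that compound's value.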